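Swapping the Ring Substituent for a tert-Butoxycarbonyl Group

A few compounds are considered here, and "the series" means these few. Any claim that something is new, unique, unknown or untested is made for them only; others in the source may bear on it.

Three compounds share one core and differ only in the group on one aromatic carbon. In an ADME assay on PC-3 cells (Homo sapiens) for cytotoxicity, read by WST assay, tested at 100 uM (on this read-out higher numbers stand for more inhibition at the one concentration tested (going by the name of the read-out) and lower numbers for less inhibition), compound 1 `O=C(Nc1cccc(N2CCCC2=O)c1)C1CCCN(C(=O)c2cc(C(F)(F)F)cc(C(F)(F)F)c2)C1` gives 0%, compound 2 `O=C(Nc1cccc(-c2ccco2)c1)C1CCCN(C(=O)c2cc(C(F)(F)F)cc(C(F)(F)F)c2)C1` gives 0%, and compound 3 `O=C(Nc1cccc(Oc2ccccn2)c1)C1CCCN(C(=O)c2cc(C(F)(F)F)cc(C(F)(F)F)c2)C1` gives 0%. Compound 3 therefore stands level with both: no change at the digits printed from compound 1 to compound 3 (within the scatter) and no change at the digits printed from compound 2 to compound 3 (within the scatter), just as no change at the digits printed from compound 1 to compound 2 (within the scatter). Compound 4 `CC(C)(C)OC(=O)c1cccc(NC(=O)C2CCCN(C(=O)c3cc(C(F)(F)F)cc(C(F)(F)F)c3)C2)c1` carries a further swap at the same place: tert-butoxycarbonyl in place of (pyridin-2-yl)oxy on an aromatic carbon. Every measured exchange there left the read-out unchanged within the scatter, so the step of no change at the digits printed from compound 3 to compound 4 (within the scatter) is expected to be none beyond the scatter as well. Compound 4 is estimated to give 0%, between -8% and 12%.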

Compound 4, a percentage reported as inhibition, at one concentration (the size of the read-out at that concentration, not a potency): 0%
Compound 4: middle estimate and measured number agree at the digits printed, and the stated range covers the measured number.
By their numbers in this assay, from the lowest: compounds 1, 2, 3 and 4 (each within the scatter of the next).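

In this assay the exchange for tert-butoxycarbonyl shows no change at the digits printed from compound 3 to compound 4 (within the scatter), along with no change at the digits printed from compound 2 to compound 4 (within the scatter) and no change at the digits printed from compound 1 to compound 4 (within the scatter). The three earlier groups at this aromatic carbon each contain a ring, whereas tert-butoxycarbonyl has no ring, so the same reading now extends to a group without one. Nothing measured here offers an explanation for this lack of difference.

On these data alone, since all four compounds read alike, it remains open whether any group at this place can shift the reading. As far as these compounds go, how an amine or a carboxylic acid would read there also stays open.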